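A few compounds are considered here, and "the series" means these few. Any claim that something is new, unique, unknown or untested is made for them only; others in the source may bear on it.

Measured compounds:
compound 1 `Cc1cc(NC(=O)Nc2cccc(Cl)c2)c2ccccc2n1` — 18000 nM
compound 2 `Cc1cc(NC(=O)Nc2ccc(F)cc2)c2ccccc2n1` — > 25000 nM
compound 3 `Cc1cc(NC(=O)Nc2ccc(O)cc2)c2ccccc2n1` — > 25000 nM

Among the measured compounds shown here, in an ADME assay on Raji cells (Homo sapiens) for cytotoxicity, with a stated time of 72 h (on this read-out higher numbers stand for an effect only at larger amounts of compound and lower numbers for an effect already at smaller amounts), compound 1 gives 18000 nM, the only actual number in the set. Compound 2 returns a limit of the assay, > 25000 nM. Compound 3 likewise returns a limit, > 25000 nM. For the measured compounds named here, compound 1 therefore stands as the single compound with a read number, the other two sitting at the limit of > 25000 nM in this assay, at which 2 of the 3 values shown sit.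

Both measured steps from compound 1 leave the chlorophenyl: an at least 1.3-fold higher number from compound 1 to compound 2 (0.14 log units; that floor lies within the scatter) and an at least 1.3-fold higher number from compound 1 to compound 3 (0.14 log units; that floor lies within the scatter). The step between the two limits, a step that the two limits leave unreadable from compound 2 to compound 3, gives no size at all.

Compound 4 `COC(=O)c1cccc(NC(=O)Nc2cc(C)nc3ccccc23)c1` changes the same ring: methoxycarbonyl in place of chloro on an aromatic carbon. Going by the values given here, no measured step covers a methoxycarbonyl, so the two steps from compound 1 are the only guide, and each of them shows only a floor that lies within the scatter. The expectation is therefore no step beyond the scatter in this assay from compound 1 to compound 4, with a real chance that compound 4 again returns only a limit. The step expected is a 1.2-fold higher number from compound 1 to compound 4 (0.09 log units; within the scatter). Compound 4 is estimated at 22000 nM, within 9000 nM to 55000 nM.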

Compound 4, half-maximal effective concentration: 26000 nM
For compound 4 the middle estimate is 1.2-fold (0.07 log units) below the measured one; the range from low to high includes it.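

In this assay, among the compounds shown here, the change from chloro to methoxycarbonyl gives a 1.4-fold higher number from compound 1 to compound 4 (0.16 log units; within the scatter), the first step from compound 1 with a readable size, as the earlier steps gave only floors. At this place, on an aromatic carbon meta to a large group, a larger group with more heavy atoms and with hydrogen-bond acceptors therefore leaves the read-out within the scatter of the chloro compound. Compound 2 and compound 3 remain limits rather than numbers, and the step between them cannot be read, so the series still rests on few read values: the limit of > 25000 nM in this assay, at which 2 of the 4 values shown sit.

Open, as far as these compounds go, is whether an amine or a carboxylic acid at this place would give a step beyond the scatter in either direction, and so whether this position can move the read-out at all. Also open, from the compounds shown here alone, is whether the methoxycarbonyl result holds elsewhere on the same ring, or alongside a longer chain on the shared core.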